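A few compounds are considered here, and "the series" means these few. Any claim that something is new, unique, unknown or untested is made for them only; others in the source may bear on it.

Measured so far in a functional assay on MGC-803 cells (Homo sapiens) for cytotoxicity, read by MTT assay, with a stated time of 3 days; a higher number here means a weaker inhibitor, a lower number a stronger inhibitor: compound 2 `Cc1cc(C)nc(Oc2ccc(NC(=O)Nc3ccc(Cl)cc3Cl)cc2)n1` with 35400 nM; compound 3 `Cc1cccc(NC(=O)Nc2ccc(Sc3nc(C)cc(C)n3)cc2)c1` with 25300 nM; compound 1 `Cc1cc(C)nc(Oc2ccc(NC(=O)Nc3ccccc3)cc2)n1` with "not determined" (no result reported), so no number is reported for it.

Compound 3 gives the lower of the two numbers, but its gap to compound 2 lies within the scatter, so the two read alike. Compound 4 `Cc1cc(C)nc(Sc2ccc(NC(=O)Nc3ccc(Cl)cc3)cc2)n1` differs from compound 3 by 4-chlorophenyl in place of 3-methylphenyl on an amide-type nitrogen. Among the measured compounds shown here, no step between measured compounds is available to calibrate this change; both measured numbers sit in the same weak range. The step from compound 3 to compound 4 is therefore expected to stay within the scatter, in no set direction: a 1.0-fold lower number from compound 3 to compound 4 (0.01 log units; within the scatter). For compound 4 the expected value in this assay is 25000 nM, with a range from 8000 nM to 70000 nM.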

Compound 4, half-maximal inhibitory concentration: 26100 nM
Beside the measured number, compound 4's estimate is 1.0-fold (0.02 log units) below it, within the range that was stated.
By their numbers in this assay, from the lowest: compounds 3, 4 and 2 (each within the scatter of the next).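

In this assay, among the compounds shown here, 4-chlorophenyl in place of 3-methylphenyl on an amide-type nitrogen gives a 1.0-fold higher number from compound 3 to compound 4 (0.01 log units; within the scatter) and is the first single-place step. At this position, these two substituted phenyl groups read alike, and both compounds stay in the same weak range. No measured property bears on this result.

Still open, on these data alone, is whether a non-phenyl group on this nitrogen, such as a pyridyl ring or a longer alkyl chain, would separate from this range. An amine or carboxylic acid on the phenyl ring is equally untested by the compounds shown.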